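Sulfur-bearing chain group in place of cyanoguanidine-type group

The source may hold more compounds than are shown below. What is called first, only, known or untested is meant among the compounds shown, and "the series" means these compounds.

Compound 1, `C/N=C(/NC#N)NCCCn1nc(-c2ccccc2)ccc1=O`, was tested in a functional assay on the whole organism (stomach) with Rattus norvegicus as the target; on this read-out higher numbers stand for an effect only at larger amounts of compound and lower numbers for an effect already at smaller amounts. In this assay compound 1 gives > 100 mg/kg, which is a limit of the assay and not a number. Compound 2, `O=c1ccc(-c2ccccc2)nn1CCCC/N=C(\S)Nc1ccc(F)cc1`, gives in this assay > 100 mg/kg, again only a limit. Compound 3, `C/N=C(/NC#N)NCCCCn1nc(-c2ccccc2)c(C)cc1=O`, gives in this assay > 100 mg/kg, also a limit. Compound 1 therefore stands nowhere apart from the others: the limit of > 100 mg/kg in this assay, at which 3 of the 3 values shown sit, so no measured step between any two of these compounds can be stated and no order among them can be drawn.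

Compound 4, `C=CCNC(=S)NCCCCn1nc(-c2ccccc2)ccc1=O`, has not yet been measured in this assay. It differs from compound 1 in one place: a group of 8 heavy atoms (5 carbon, 2 nitrogen, 1 sulfur; no ring) in place of a group of 7 heavy atoms (3 carbon, 4 nitrogen; no ring), on a saturated chain carbon, three bonds along the chain from an aromatic nitrogen. With every measured compound sitting at the same limit, the step of a number no higher from compound 1 to compound 4 (the limit leaves the size open) is expected to be none beyond the scatter. Compound 4 is thus expected to give about 100 mg/kg in this assay, within 40 mg/kg to 300 mg/kg, most probably again only as a limit.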

Compound 4, dose for half-maximal effect: > 100 mg/kg
Compound 4 was reported as a limit; the forecaster's own chance of this, stated with the estimate: 75%; the middle value lies on the limit itself.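

No step from compound 1 to compound 4 can be read, since the value of compound 4 is again only a limit of the assay and not a number: the limit of > 100 mg/kg in this assay, at which 4 of the 4 values shown sit.

The compounds shown leave open what dose, if any, gives a half-maximal effect in this assay, and whether the exchanged chain group changes it.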